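Extending a Side Chain by One Carbon in a Lactam Series

The source may report more compounds than this note shows. Statements on the series, on what has been measured and on what is new or still open speak of the compounds shown alone.

Measured so far:
compound 1, `C=CCCC1CN([Si](C)(C)C(C)(C)C)C1=O`: 49.5%
compound 2, `C=CCCC(=O)N1CC(CC=C)C1=O`: 96.5%

Of the compounds shown here, two have been measured. In an assay for inhibition of Fatty-acid amide hydrolase 1 (Homo sapiens), tested at 1 mM (on this read-out lower numbers stand for less inhibition and higher numbers for more inhibition at the one concentration tested (going by the name of the read-out)), compound 1 gives 49.5%, while compound 2 gives 96.5%. Among the measured compounds shown here, compound 2 thus stands highest of the two numbers; its only neighbour, compound 1, lies lower by a gap beyond the usual scatter. For the measured compounds named here, the two differ in more than one place, so no single step is defined between them, and their values show only that compound 2 is the higher of the pair.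

Compound 3, `C=CCCC(=O)N1CC(CCC=C)C1=O`, is not yet measured. It differs from compound 2 as follows: allyl in place of vinyl on a saturated chain carbon bound to a saturated ring carbon. Because compound 2 already reaches 96.5%, compound 3 is expected to sit near the same level. The step of a number 3.5 percentage points lower from compound 2 to compound 3 (within the scatter) is expected to stay within the scatter. Compound 3 is estimated at 93%, within a range from 75% to 100%.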

Compound 3, a percentage reported as inhibition, at one concentration (the size of the read-out at that concentration, not a potency): 103%
Compound 3: middle estimate off by 10 percentage points, on the low side; measured number above the stated range.
By their numbers in this assay, from the lowest: compound 1; then compounds 2 and 3 (each within the scatter of the next).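

In this assay, putting allyl in place of vinyl on a saturated chain carbon bound to a saturated ring carbon gives a number 6.5 percentage points higher from compound 2 to compound 3 (within the scatter). Among the compounds shown here, this is the first comparison at this position that differs in one place only, and it shows that this change leaves the read-out within the scatter, so compound 2 and compound 3 cannot be ranked against each other. No supporting evidence bears on this result.

Going by these compounds, what remains open is whether the same level would hold with a longer chain at this position, or with an amine or a carboxylic acid at the end of the chain. As each compound has a number at one concentration only, the compounds also leave open whether compound 2 and compound 3 would stay level at lower concentrations.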